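One Added Hydroxy on the Ester Side Chain

This account rests on a few compounds, and the source may have more. Where it says the series, first, only, none or still open, it means among the compounds named here.

Measured in a physicochemical assay for solubility, read by nephelometry, measured as kinetic solubility; a lower number here means a less soluble compound, a higher number a more soluble compound:
Compound 1 `CCC/N=C1\S/C(=C\c2ccc(C(=O)NCC(=O)N(C)C)cc2)C(=O)N1c1ccccc1O`: 219000 nM
Compound 2 `CCC/N=C1\S/C(=C\c2ccc(C(=O)OCCCO)cc2)C(=O)N1c1ccccc1O`: 183000 nM

Going by the values given here, compound 2 gives 183000 nM, and this value lies within the scatter of the only other number available, that of compound 1. Compound 3 `CCC/N=C1\S/C(=C\c2ccc(C(=O)OCC(O)CO)cc2)C(=O)N1c1ccccc1O` differs from compound 2 by a single change, (hydroxy in place of hydrogen on a saturated chain carbon bound to two saturated chain carbons), which turns 3-hydroxypropoxy into 2,3-dihydroxypropoxy. Among the compounds with values here, no measured step makes this same change, so the data offer no direct precedent. The closest evidence is a different exchange on a carbonyl carbon, a 1.2-fold lower number from compound 1 to compound 2 (0.08 log units; within the scatter). Within the data shown here, with only that small step to go on, no shift beyond the scatter is expected in this assay, and any direction would be weakly supported. The expected result is a 1.1-fold higher number from compound 2 to compound 3 (0.04 log units; within the scatter). For compound 3 the estimated value is 200000 nM, with an expected range from 120000 nM to 320000 nM.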

Compound 3, solubility: > 250000 nM
Compound 3 ended at the assay's limit; the forecaster's own chance of this, stated with the estimate: 10%; middle value at least 1.2-fold (0.09 log units) from the limit.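

In this assay compound 3 gives > 250000 nM as its reading, which is a limit of the assay and not a number. Hydroxy in place of hydrogen on a saturated chain carbon bound to two saturated chain carbons gives an at least 1.3-fold higher number from compound 2 to compound 3 (0.13 log units; that floor lies within the scatter) as the first reading for this position on the chain, and the exchange of the whole side chain on the carbonyl carbon gives an at least 1.1-fold higher number from compound 1 to compound 3 (0.05 log units; that floor lies within the scatter) as its step. Only these floors can be read, because compound 3 sits at the top of the readable range: the limit of > 250000 nM in this assay, at which 1 of the 3 values shown sits.

Going by these compounds, whether the true step from the 3-hydroxypropoxy ester lies beyond the scatter remains open. Also open, on these data alone, is how an amine or a carboxylic acid on this chain carbon, or a longer chain carrying the same hydroxy groups, would read in this assay on the shared core.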